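Thiourea pyrazolines with a benzodioxane unit: a methyl addition

The source may report more compounds than this note shows. Statements on the series, on what has been measured and on what is new or still open speak of the compounds shown alone.

Three members of the series carry numbers in a functional assay on HT-29 cells (Homo sapiens) for antiproliferative activity, read by MTT assay, with a stated time of 48 h; a lower number here means a stronger inhibitor of growth, a higher number a weaker inhibitor of growth. Compound 1, `S=C(Nc1ccccc1)N1N=C(c2ccc(Br)cc2)CC1c1ccc2c(c1)OCCO2`, gives 2580 nM in this assay. Compound 2, `Cc1ccc(C2=NN(C(=S)Nc3ccccc3)C(c3ccc4c(c3)OCCO4)C2)cc1`, gives 19500 nM in this assay, and this is the highest of the two plain numbers, standing a 7.6-fold higher number from compound 1 to compound 2 (0.88 log units; beyond the scatter). Compound 3, `S=C(Nc1ccccc1)N1N=C(c2ccccc2Br)CC1c1ccc2c(c1)OCCO2`, reaches only the limit of > 200000 nM in this assay, at which 1 of the 3 values shown sits, and so gives > 200000 nM in this assay, a limit and not a number.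

The step to be followed runs from compound 2 to compound 4, `Cc1ccc(C2=NN(C(=S)Nc3ccccc3)C(c3ccc4c(c3)OCCO4)C2)cc1C`, with the difference (methyl in place of hydrogen on an aromatic carbon). Among the measured compounds shown here, no measured step is of the same kind. The step from compound 1 to compound 2, methyl in place of bromo on an aromatic carbon, was a 7.6-fold higher number from compound 1 to compound 2 (0.88 log units; beyond the scatter). The steps to compound 3, 2-bromophenyl in place of 4-bromophenyl and 2-bromophenyl in place of 4-methylphenyl, were an at least 77-fold higher number from compound 1 to compound 3 (1.88 log units; beyond the scatter) and an at least 10-fold higher number from compound 2 to compound 3 (1.01 log units; beyond the scatter); both change the position of a substituent rather than add one.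

A methyl added where a single heavy atom enters is expected to move the number little, if at all beyond the scatter, in either direction. For compound 4 the estimated value in this assay is 22000 nM, with a range from 7000 nM to 70000 nM; the expected step is a 1.1-fold higher number from compound 2 to compound 4 (0.05 log units; within the scatter).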

Compound 4, concentration for 50% growth inhibition: 133000 nM
Beside the measured number, compound 4's estimate is 6.0-fold (0.78 log units) below it, outside the stated range (above it).
By their numbers in this assay, from the lowest: compound 1; then compound 2; then compound 4. At a limit, above all of these: compound 3.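

In this assay, among the compounds shown here, the change from 4-methylphenyl to 3,4-dimethylphenyl, with methyl in place of hydrogen at the ring position ortho to a methyl group and meta to a large group, is the first measured step of this kind and gives a 6.8-fold higher number from compound 2 to compound 4 (0.83 log units; beyond the scatter). The 3,4-dimethylphenyl group also lies well away from the 4-bromophenyl group, a larger gap than the one opened by the methyl-for-bromo change alone: a 52-fold higher number from compound 1 to compound 4 (1.71 log units; beyond the scatter). Compound 3 sits at a limit and not a number: the limit of > 200000 nM in this assay, at which 1 of the 4 values shown sits. Measured against that limit, the step has only a floor, and that floor lies within the scatter: an at least 1.5-fold lower number from compound 3 to compound 4 (0.17 log units; that floor lies within the scatter).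

The compounds shown give no cause for the loss of growth inhibition on adding this methyl. Going by these compounds, it stays open whether the same position would respond in the same way to an amine, a carboxylic acid or a longer chain such as ethyl, and whether a group there would matter equally with bromo rather than methyl on the neighbouring ring carbon.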